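The compounds below may be only part of what the source reports. "The series", "measured", "known", "first", "only" and "open" are said of these compounds alone.

Of the compounds shown here, three with a shared core have been tested in a functional assay on HUVEC cells (Homo sapiens), read by scintillation counting and thymidine incorporation, with a stated time of 24 h (a lower number here means a stronger inhibitor, a higher number a weaker inhibitor), and they differ only in the group on a saturated chain carbon bound to a saturated ring carbon. Compound 1 `CCC(C)n1ncn(-c2ccc(N3CCN(c4ccc(OC[C@@H]5CO[C@@](CC)(c6ccc(Cl)cc6Cl)O5)cc4)CC3)cc2)c1=O` gives 353 nM, compound 2 `CCC(C)n1ncn(-c2ccc(N3CCN(c4ccc(OC[C@@H]5CO[C@@](CN(C)C)(c6ccc(Cl)cc6Cl)O5)cc4)CC3)cc2)c1=O` gives 1400 nM, and compound 3 `CCC(C)n1ncn(-c2ccc(N3CCN(c4ccc(OC[C@@H]5CO[C@@](CN6CCN(C)CC6)(c6ccc(Cl)cc6Cl)O5)cc4)CC3)cc2)c1=O` gives 396 nM. Compound 3 thus stands level with compound 1, as the data show a 1.1-fold higher number from compound 1 to compound 3 (0.05 log units; within the scatter). Compound 2 stands apart, with a 4.0-fold higher number from compound 1 to compound 2 (0.60 log units; beyond the scatter) and a 3.5-fold lower number from compound 2 to compound 3 (0.55 log units; beyond the scatter).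

The next compound, compound 4 `CCC(C)n1ncn(-c2ccc(N3CCN(c4ccc(OC[C@@H]5CO[C@@](Cn6cnc(C)n6)(c6ccc(Cl)cc6Cl)O5)cc4)CC3)cc2)c1=O`, has not yet been measured. It differs from compound 3 as follows: 3-methyl-1H-1,2,4-triazol-1-yl in place of 4-methylpiperazin-1-yl on a saturated chain carbon bound to a saturated ring carbon. A six-membered non-aromatic ring therefore gives way to a five-membered aromatic ring. Within the data shown here, no measured step makes this exact swap. The three steps at this place range from none beyond the scatter to modest, and they point to no direction for a new group, so no step beyond the scatter is expected in this assay. The expected outcome is a 1.0-fold higher number from compound 3 to compound 4 (0.00 log units; within the scatter). For compound 4 the estimated value is 400 nM, with an expected range of 150 nM to 1100 nM.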

Compound 4, half-maximal inhibitory concentration: 272 nM
For compound 4 the middle estimate is 1.5-fold (0.17 log units) above the measured one; low and high end bracket the measured number.
By their numbers in this assay, from the lowest: compounds 4, 1 and 3 (each within the scatter of the next); then compound 2.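

With 3-methyl-1H-1,2,4-triazol-1-yl, the only aromatic ring at this place among the compounds shown, this assay gives a 1.5-fold lower number from compound 3 to compound 4 (0.16 log units; within the scatter) against 4-methylpiperazin-1-yl and a 1.3-fold lower number from compound 1 to compound 4 (0.11 log units; within the scatter) against methyl, so this assay does not separate the five-membered aromatic ring from the six-membered non-aromatic ring or from the smaller group. Dimethylamino remains the one group set apart, with a 5.1-fold lower number from compound 2 to compound 4 (0.71 log units; beyond the scatter) showing that its gap extends to the new ring as well. Nothing measured here explains why these groups read as they do.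

As far as these compounds go, whether an imidazol-1-yl ring or a triazole without the methyl would give a similar reading remains open, and so does the effect of a carboxylic acid on this carbon. It is also unknown whether another open-chain amine, such as diethylamino, would read like dimethylamino or like the ring-bearing compounds.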